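Chloro to methoxy exchange in two paired compounds

The source may report more compounds than this note shows. Statements on the series, on what has been measured and on what is new or still open speak of the compounds shown alone.

Compound 1 `CC(Br)C(=O)Nc1ccc(C(=O)/C=C/c2ccc(Cl)cc2)cc1` and compound 2 `COc1ccc(/C=C/C(=O)c2ccc(NC(=O)C(C)Br)cc2)cc1` share one core; compound 3 `O=C(COCc1c(-c2ccccc2)no[n+]1[O-])Nc1ccc(C(=O)/C=C/c2ccc(Cl)cc2)cc1` and compound 4 `COc1ccc(/C=C/C(=O)c2ccc(NC(=O)COCc3c(-c4ccccc4)no[n+]3[O-])cc2)cc1` share another. How the core of compound 3 differs from the core of compound 1 is not broken down here.

In a functional assay on the whole organism (strain albino) for inhibition, with Rattus norvegicus as the target, read by paw edema, with stated times of 30 min and 1 h, at a dose of 100 mg/kg by the oral route (on this read-out lower numbers stand for less inhibition and higher numbers for more inhibition at the one dose given (going by the name of the read-out)), compound 1 gives 39%. In this assay compound 2 gives 39%. The two are linked by the change (methoxy in place of chloro on an aromatic carbon); the step of no change at the digits printed from compound 1 to compound 2 (within the scatter). In this assay compound 3 gives 38%, a number within the scatter of both compound 1 and compound 2, so no order among the three measured compounds can be read from these numbers.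

Compound 4 has not yet been measured in this assay. Within the data shown here, it arises from compound 3 by the change (methoxy in place of chloro on an aromatic carbon), the same change as the one from compound 1 to compound 2, at the same kind of place on the ring; the two place descriptions read alike word for word. What differs is only the rest of the molecule, the cores of compound 3 and compound 1, and that difference is not broken down here.

The expectation rests on compound 1 and compound 2, whose step no change at the digits printed from compound 1 to compound 2 (within the scatter) stayed within the scatter under this change. The step from compound 3 to compound 4 is therefore expected to be no change at the digits printed from compound 3 to compound 4 (within the scatter), that is, essentially flat. Compound 4 is estimated at 38%, with a likely range from 28% to 48%.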

Compound 4, a percentage reported as inhibition, in the whole organism at one dose (the size of the read-out at that dose, not a potency): 30%
Compound 4: middle estimate off by 8 percentage points, on the high side; the measured number falls inside the stated range.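

In this assay, the exchange of chloro for methoxy on the second core gives a number 8 percentage points lower from compound 3 to compound 4 (within the scatter). Set beside the same exchange on the first core, the two steps cannot be told apart: the same change on two cores in this assay, no change at the digits printed (within the scatter) from compound 1 to compound 2 and a number 8 percentage points lower (within the scatter) from compound 3 to compound 4, 8 percentage points apart, within the scatter of two such steps. This shows that, across these two cores and at the one dose given, the exchange from 4-chlorophenyl to 4-methoxyphenyl gives no step beyond the scatter on either core, and that the first core's result is not contradicted on the second; it does not show that the two steps are truly equal, that the exchange is without effect on every core, or why either step has the size it has, since two pairs at a single dose can only fail to separate.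

The compounds shown leave open how the series responds when the place on the aromatic ring carries a group other than chloro or methoxy, for example an amine, a carboxylic acid or a longer chain such as ethoxy. They also leave open whether the two cores would part under such a group, or whether the steps would stay as close as they do for this exchange.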